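From nitrotriazole to nitroimidazole: working notes on the series

The source may report more compounds than this note shows. Statements on the series, on what has been measured and on what is new or still open speak of the compounds shown alone.

Measured so far in an ADME assay on L6 cells (Rattus norvegicus) for cytotoxicity, read by luminescence and CellTiter-Glo, with a stated time of 2 days; on this read-out higher numbers stand for weaker inhibition and lower numbers for stronger inhibition:
- Compound 1 `Clc1cccc2c(NCCCCn3cncn3)ccnc12`: 37700 nM
- Compound 2 `O=[N+]([O-])c1ncn(CCCCNc2ccnc3c(Cl)cccc23)n1`: 73600 nM

For the measured compounds named here, with only two numbers available, compound 2 has no measured neighbour beyond the scatter: the one comparison is a 2.0-fold higher number from compound 1 to compound 2 (0.29 log units; within the scatter). Compound 3 `O=[N+]([O-])c1nccn1CCCCNc1ccnc2c(Cl)cccc12` is still unmeasured. It differs from compound 2 by 2-nitro-1H-imidazol-1-yl in place of 3-nitro-1H-1,2,4-triazol-1-yl on a saturated chain carbon, four bonds along the chain from a nitrogen on an aromatic ring.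

That one measured step bears on this change only loosely. It adds nitro in place of hydrogen on an aromatic carbon, whereas the new change keeps the nitro group and exchanges the ring carrying it. Going by the values given here, no measured step covers such an exchange, so the evidence is thin. Among the compounds with values here, the only guide is a step that stayed within the scatter, so no step beyond the scatter, in either direction, is expected in this assay. The estimated change is a 1.5-fold lower number from compound 2 to compound 3 (0.17 log units; within the scatter). For compound 3 the estimated value is 50000 nM, with an expected range of 20000 nM to 120000 nM.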

Compound 3, half-maximal inhibitory concentration: 36200 nM
Beside the measured number, compound 3's estimate is 1.4-fold (0.14 log units) above it, within the range that was stated.
By their numbers in this assay, from the lowest: compounds 3, 1 and 2 (each within the scatter of the next, the first and the last beyond it).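

In this assay, for the compounds shown here, 2-nitro-1H-imidazol-1-yl in place of 3-nitro-1H-1,2,4-triazol-1-yl on a saturated chain carbon, four bonds along the chain from a nitrogen on an aromatic ring, gives a 2.0-fold lower number from compound 2 to compound 3 (0.31 log units; beyond the scatter) and is the only one of the three steps printed as beyond the scatter, which shows that exchanging the ring carrying the nitro group can register at this position, though only modestly. 2-Nitro-1H-imidazol-1-yl in place of 1H-1,2,4-triazol-1-yl at the same position gives a 1.0-fold lower number from compound 1 to compound 3 (0.02 log units; within the scatter) and so leaves the two numbers inseparable, which shows that a nitro-bearing ring at this position need not give a number apart from that of the ring without nitro. Nothing measured alongside these numbers accounts for the difference between the two nitro-bearing rings.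

On these data alone, whether the step between the two nitro-bearing rings persists with a longer chain, or with an amine or a carboxylic acid in place of the nitro group, stays open. Also open, as far as these compounds go, is whether a step this modest would hold up on repeated measurement in this assay.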